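A few compounds are considered here, and "the series" means these few. Any claim that something is new, unique, unknown or untested is made for them only; others in the source may bear on it.

Working notes on the series. Compound 2 `CN(c1ccc2cc(NC(=O)CCc3ccc(C(F)(F)F)cc3)ccc2n1)C1CCCCC1` holds the higher of the two numbers obtained so far in an assay on isolated protein for displacement of a labelled ligand from melanin-concentrating hormone receptor 1 (Homo sapiens); a higher number here means a weaker inhibitor, a lower number a stronger inhibitor: compound 2 gives 18 nM, while compound 1 `O=C(CCc1ccc(C(F)(F)F)cc1)Nc1ccc2nc(N3CCC3)ccc2c1` gives 4 nM. Among the measured compounds shown here, the single measured step is a 4.5-fold higher number from compound 1 to compound 2 (0.65 log units; beyond the scatter). Compound 3 `O=C(CCc1ccc(C(F)(F)F)cc1)Nc1ccc2nc(N3CCC4(CCNC4)C3)ccc2c1` is the next member to be tested. Relative to compound 2 the change is a group of 9 heavy atoms (7 carbon, 2 nitrogen; 2 five-membered non-aromatic rings with 1 hetero atom each) in place of a group of 8 heavy atoms (7 carbon, 1 nitrogen; one six-membered non-aromatic ring of carbon only), on an aromatic carbon. The step from compound 1 to compound 2 is the one that bears on it: it exchanged one amine on that aromatic carbon for another and moved the number beyond the scatter, so this position can shift the read-out by that much. Compound 3 returns to an amine joined through a ring nitrogen, as in compound 1, and is therefore expected to move the number back in that direction, by a step estimated at a 3.0-fold lower number from compound 2 to compound 3 (0.48 log units; beyond the scatter). For the measured compounds named here, no measured step shows how the second ring and the donor it carries behave, so the range is kept wide. For compound 3 the expected value in this assay is 6 nM, within a range from 2 nM to 25 nM.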

Compound 3, half-maximal inhibitory concentration: 0.5 nM
The estimate for compound 3 lay 12-fold (1.08 log units) above the measured number; measured number outside the range, below it.
By their numbers in this assay, from the lowest: compound 3; then compound 1; then compound 2.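

In this assay, the group of 9 heavy atoms on the aromatic carbon next to the ring nitrogen gives a 36-fold lower number from compound 2 to compound 3 (1.56 log units; beyond the scatter), a large step, so this position can shift the number much further than the earlier amine exchange showed. Against the azetidin-1-yl group the same group gives an 8.0-fold lower number from compound 1 to compound 3 (0.90 log units; beyond the scatter), so the number falls beyond the scatter relative to both earlier amines, and heavy-atom count alone does not order the three compounds: the count of 8 in compound 2 goes with the highest number, while the count of 4 in compound 1 and the count of 9 in compound 3 both go with a lower number. Nothing measured on hand accounts for this result.

The compounds shown do not separate the contribution of the second ring from that of the hydrogen-bond donor it carries, a question that a methyl group on that ring nitrogen, or an oxygen in its place, would address. As far as these compounds go, the amide chain and the trifluoromethyl group are the same in all three compounds, so it remains open whether the gain would persist with a nitrile in place of trifluoromethyl or with a longer chain.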